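From compound 2 to compound 3: a new amine substituent

A few compounds are considered here, and "the series" means these few. Any claim that something is new, unique, unknown or untested is made for them only; others in the source may bear on it.

Of the compounds shown here, two have values so far in a functional assay on B16 cells (Mus musculus) for inhibition; a lower number here means a stronger inhibitor, a higher number a weaker inhibitor. Compound 1, `CC(C)CN(NC(=O)OCc1ccccc1)C(=O)CN(Cc1ccccc1)NC(=O)CBr`, gives 1800 nM, and compound 2, `CC(C)CN(CC(=O)NN(Cc1ccccc1)c1cnccn1)NC(=O)CBr`, gives 14800 nM. Compound 2 holds the higher of the two numbers, which makes it the weaker inhibitor of the pair, and the gap to compound 1 lies beyond the usual scatter. The two compounds do not differ in just one place, so this gap says nothing about any single group.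

Compound 3, `CC(C)CN(CC(=O)NN(Cc1ccccc1)c1cnccn1)/N=C/c1cccc(B(O)O)c1`, has not yet been measured. It departs from compound 2 on an amine nitrogen whose other neighbours are a saturated chain carbon and a saturated chain carbon: a group of 11 heavy atoms (7 carbon, 1 boron, 1 nitrogen, 2 oxygen; one six-membered aromatic ring of carbon only) in place of a group of 5 heavy atoms (2 carbon, 1 nitrogen, 1 oxygen, 1 bromine; no ring), on an amine nitrogen. The ((bromomethyl)carbonyl)amino group leaves, and the entering group brings boron and a six-membered aromatic ring of carbon only. Going by the values given here, the series offers no measured single-place step to calibrate this change. No step beyond the scatter is expected in this assay, with wide uncertainty in both directions. The expected change is a 1.5-fold lower number from compound 2 to compound 3 (0.17 log units; within the scatter). Compound 3 is estimated at 10000 nM, with an expected range of 2000 nM to 50000 nM.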

Compound 3, half-maximal inhibitory concentration: 33700 nM
Compound 3: the middle estimate sits 3.4-fold (0.53 log units) below what was measured, within the range that was stated.
By their numbers in this assay, from the lowest: compound 1; then compound 2; then compound 3.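

In this assay, this pair gives the series its first single-place step on the amine nitrogen whose other neighbours are saturated chain carbons: the step is a 2.3-fold higher number from compound 2 to compound 3 (0.36 log units; beyond the scatter) and it is modest, towards weaker inhibition. Inhibition does not depend on keeping the ((bromomethyl)carbonyl)amino group at this position, as compound 3 lacks that group and still gives 33700 nM, so the entering group with its boron and six-membered aromatic ring of carbon only is accepted there at a modest loss. Nothing available bears on what lies behind this step.

The step combines the loss of the ((bromomethyl)carbonyl)amino group with the entry of the new one, so the share of the boron in the outcome stays unresolved; the same entering group with a carboxylic acid in place of the boron-bearing group, or with a plain hydrogen there, would separate these contributions. Also open, on these data alone, is whether the same exchange on the core of compound 1 would give a step of similar size and direction.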